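This account rests on a few compounds, and the source may have more. Where it says the series, first, only, none or still open, it means among the compounds named here.

Measured compounds:
- compound 1 `COc1cccc2ccc(Nc3cc(Cl)ccn3)nc12`: 11900 nM
- compound 2 `COc1ccc(Cl)c2ccc(Nc3ccccn3)nc12`: 29200 nM
- compound 3 `Oc1cccc2ccc(Nc3cc(Cl)ccn3)nc12`: 2810 nM

All three values come from a functional assay on PC-3 cells (Homo sapiens) for antiproliferative activity, read by MTT assay, with a stated time of 96 h; on this read-out higher numbers stand for weaker inhibition of growth and lower numbers for stronger inhibition of growth. Compound 1 and compound 2 are built from the same atoms joined differently; the difference between the two cores is not broken down here. Compound 3 differs from compound 1 by hydrogen in place of methyl on an oxygen on an aromatic ring, and this change gave a 4.2-fold lower number from compound 1 to compound 3 (0.63 log units; beyond the scatter).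

Compound 4 `Oc1ccc(Cl)c2ccc(Nc3ccccn3)nc12` is not yet measured. It differs from compound 2 by hydrogen in place of methyl on an oxygen on an aromatic ring, the same change made at the same kind of place as from compound 1 to compound 3. For the measured compounds named here, on the single measured instance of this change, the step of a 4.2-fold lower number from compound 2 to compound 4 (0.62 log units; beyond the scatter) is expected, resting on compound 3 being stronger than compound 1 in this assay by a 4.2-fold lower number from compound 1 to compound 3 (0.63 log units; beyond the scatter). Compound 4 is therefore estimated at 7000 nM, with a range from 2500 nM to 20000 nM given that one precedent only.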

Compound 4, concentration for 50% growth inhibition: 1290 nM
Compound 4: middle estimate off by 5.4-fold (0.73 log units), on the high side; the whole stated range lies above it.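

Methoxy to hydroxy lowered the number on both cores in this assay, so the direction of the change carried over, and on the second core the result was a 23-fold lower number from compound 2 to compound 4 (1.35 log units; beyond the scatter). The size of the step did not carry over: the same change on two cores in this assay, a 4.2-fold lower number (0.63 log units; beyond the scatter) from compound 1 to compound 3 and a 23-fold lower number (1.35 log units; beyond the scatter) from compound 2 to compound 4, 5.3-fold (0.73 log units) apart, beyond the scatter of two such steps
This pair shows that a step measured on one core gave the direction but not the size on the other; it does not show which difference between the cores sets the size, or how the step would run on a further core.

Still open, as far as these compounds go, is how other groups on the same oxygen, such as ethyl or acetyl, would compare with hydroxy on these two cores. From the compounds shown here alone, an amine in place of hydroxy is equally open.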